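Swapping cyano for nitro on the sulfonyl aryl ring

The source may report more compounds than this note shows. Statements on the series, on what has been measured and on what is new or still open speak of the compounds shown alone.

Compound 2 `CNC(=O)/C=C1/COc2cc(OS(=O)(=O)c3ccc(C#N)cc3)ccc21` gives 45 nM in an assay (strain Sprague-Dawley) for inhibition of Amine oxidase [flavin-containing] A (Rattus norvegicus), read by spectrophotometry, with a stated time of 5 min (a lower number here means a stronger inhibitor, a higher number a weaker inhibitor), and stands at one end of the two numbers shown; compound 1 `CNC(=O)/C=C1/COc2cc(OS(=O)(=O)c3cccc(F)c3)ccc21` gives 41 nM in this assay, with a 1.1-fold higher number from compound 1 to compound 2 (0.04 log units; within the scatter) lying within the scatter. Compound 3 `CNC(=O)/C=C1/COc2cc(OS(=O)(=O)c3ccc([N+](=O)[O-])cc3)ccc21` differs from compound 2 by nitro in place of cyano on an aromatic carbon. Among the measured compounds shown here, only the step from compound 1 to compound 2 bears on this change, and since it was small, no step beyond the scatter is expected in this assay. Compound 3 is therefore expected to give 50 nM, between 25 nM and 100 nM, which means an expected step of a 1.1-fold higher number from compound 2 to compound 3 (0.05 log units; within the scatter).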

Compound 3, half-maximal inhibitory concentration: 37 nM
Beside the measured number, compound 3's estimate is 1.4-fold (0.13 log units) above it; the measured number falls inside the stated range.
By their numbers in this assay, from the lowest: compounds 3, 1 and 2 (each within the scatter of the next).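

In this assay, nitro replaces cyano on the aromatic carbon para to a large group and gives a 1.2-fold lower number from compound 2 to compound 3 (0.09 log units; within the scatter). Replacing 3-fluorophenyl on the sulfonyl sulfur with 4-nitrophenyl gives a 1.1-fold lower number from compound 1 to compound 3 (0.04 log units; within the scatter). These three aryl groups therefore cannot be told apart in this assay, and no measurement here offers an explanation for that. Still open, on these data alone, is whether an amine, a carboxylic acid or a longer chain on this aromatic carbon would also leave the number within the scatter.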